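Cytotoxicity notes: amino side chain variation on the shared core

A few compounds are considered here, and "the series" means these few. Any claim that something is new, unique, unknown or untested is made for them only; others in the source may bear on it.

Measured so far in an ADME assay on cells (Homo sapiens) for cytotoxicity, read by polymerase chain reaction, with a stated time of 3 days; on this read-out higher numbers stand for lower toxicity in this test and lower numbers for higher toxicity in this test:
- compound 1 `Nc1nc(Cl)c(-c2ccccn2)c(N[C@@H]2C[C@H](CO)[C@@H](O)[C@H]2O)n1`: > 25000 nM, a limit of the assay
- compound 2 `Cc1nc(NCC2CC2)nc(N[C@@H]2C[C@H](CO)[C@@H](O)[C@H]2O)c1-c1nc2ccccc2s1`: 8000 nM
- compound 3 `CCOCCNc1nc(C)c(-c2nc3ccccc3s2)c(N[C@@H]2C[C@H](CO)[C@@H](O)[C@H]2O)n1`: 18000 nM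

Compound 1 sits at a limit, (the limit of > 25000 nM in this assay, at which 1 of the 3 values shown sits), and gives no number. Of the two numbers shown, compound 3 stands highest, with compound 2 the nearest; the only step between measured compounds that differ in one place is a 2.3-fold higher number from compound 2 to compound 3 (0.35 log units; beyond the scatter), a modest rise that is nonetheless beyond the scatter.

Compound 4 `Cc1nc(NCc2cccs2)nc(N[C@@H]2C[C@H](CO)[C@@H](O)[C@H]2O)c1-c1nc2ccccc2s1` is not yet measured in this assay. It differs from compound 3 at the same place as that step: thiophen-2-yl in place of ethoxymethyl on a saturated chain carbon bound to a nitrogen on an aromatic ring. Within the data shown here, no measured step exchanges an ethoxymethyl for an aromatic ring at this position, so the step from compound 2 to compound 3 is the only guide, and it is a loose one. The two numbers available span a modest range, and compound 4 is expected to fall within or near that range. A modest lower number is expected, a 2.0-fold lower number from compound 3 to compound 4 (0.30 log units; within the scatter), placing compound 4 nearer compound 2 than compound 3, while the width of the range allows for no change beyond the scatter. Compound 4 is thus estimated at 9000 nM, between 3500 nM and 25000 nM.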

Compound 4, half-maximal cytotoxic concentration: 6000 nM
Beside the measured number, compound 4's estimate is 1.5-fold (0.18 log units) above it, within the range that was stated.
By their numbers in this assay, from the lowest: compounds 4 and 2 (each within the scatter of the next); then compound 3. At a limit, above all of these: compound 1.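

In this assay, thiophen-2-yl in place of ethoxymethyl on a saturated chain carbon bound to a nitrogen on an aromatic ring gives a 3.0-fold lower number from compound 3 to compound 4 (0.48 log units; beyond the scatter), so this position has now moved the read-out in both directions, and the earlier rise seen with ethoxymethyl is reversed by a second, different group. The other new comparison, a 1.3-fold lower number from compound 2 to compound 4 (0.12 log units; within the scatter), stays within the scatter, which leaves cyclopropyl and thiophen-2-yl unseparated even though one ring is saturated and the other aromatic; among these three compounds, which share the core and differ only at this position, the one group without a ring, ethoxymethyl, carries the highest number, and none of the three goes against this. Nothing measured here accounts for these differences.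

Still open, on these data alone, is whether the ether oxygen or the absence of a ring goes with the higher number, a question that a plain butyl chain at this position would help to separate from the ring question. A terminal amine or carboxylic acid on the chain, or a phenyl group in place of thiophen-2-yl, would show how far this narrow pattern extends.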